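A few compounds are considered here, and "the series" means these few. Any claim that something is new, unique, unknown or untested is made for them only; others in the source may bear on it.

Measured so far in a functional assay on MCF7 cells (Homo sapiens) for cytotoxicity, read by MTT assay, with a stated time of 72 h; on this read-out lower numbers stand for higher toxicity in this test and higher numbers for lower toxicity in this test:
Compound 1 `N#C[Se]c1ccc(NC(=O)OCc2ccc([N+](=O)[O-])cc2)cc1` gives 69500 nM in this assay.
Compound 2 `C=CCOC(=O)Nc1ccc([Se]C#N)cc1` gives 71200 nM in this assay.
Compound 3 `O=C(Nc1ccc([Se][Se]c2ccc(NC(=O)OCc3ccc([N+](=O)[O-])cc3)cc2)cc1)OCc1ccc([N+](=O)[O-])cc1` gives 85000 nM in this assay.

Compound 2 stands second highest of the three numbers. Its nearest neighbour is compound 1, within the scatter, and its furthest is compound 3, also within the scatter; the three values therefore show no separation beyond repeat variation, whether the carbamate carries a nitrobenzyl group, an allyl group, or the diselenide links two carbamate units.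

Compound 4 `CCOC(=O)Nc1ccc([Se]C#N)cc1` is not yet measured. It differs from compound 2 in one place: methyl in place of vinyl on a saturated chain carbon bound to an oxygen next to a carbonyl group. Within the data shown here, no step between measured compounds is available to size a change of this kind, and the measured set as a whole gives no sign that such a substituent sets the read-out. The expected step is a 1.0-fold higher number from compound 2 to compound 4 (0.00 log units; within the scatter), that is, none beyond the scatter in either direction. Compound 4 is accordingly estimated to give 72000 nM, with a range from 36000 nM to 145000 nM.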

Compound 4, concentration lethal to 50% of the cells: 67800 nM
Estimate against measurement, compound 4: 1.1-fold (0.03 log units) above; measured number inside the range.
By their numbers in this assay, from the lowest: compounds 4, 1, 2 and 3 (each within the scatter of the next).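

In this assay, methyl in place of vinyl on the saturated chain carbon bound to an oxygen next to a carbonyl group gives a 1.1-fold lower number from compound 2 to compound 4 (0.02 log units; within the scatter). Among these compounds, this is the first step that isolates one place, and it shows that the allyl to ethyl change, which removes the double bond outside aromatic rings, leaves the read-out within repeat variation. No measurement available bears on why this change makes so little difference.

Going by these compounds, whether an amine or a carboxylic acid on this chain, or a longer chain, would shift the number beyond the scatter stays open. The allyl to ethyl step covers only a small change in chain, and it says nothing about replacing the nitrile on selenium.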